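The source may report more compounds than this note shows. Statements on the series, on what has been measured and on what is new or still open speak of the compounds shown alone.

Of the compounds shown here, two have been tested in a functional assay on HT-29 cells (Homo sapiens) for cytotoxicity; a higher number here means that more compound is needed for the effect, a lower number that less compound is needed. Compound 1 (`CC(=O)[C@H]1[C@@H](OC=O)CCC2=C[C@@H](O)C[C@H](C)[C@]21C`) gives > 5 ug/mL, which is a limit and not a number. Compound 2 (`CC(=O)[C@H]1[C@@H](O)CCC2=C[C@H](O)C[C@H](C)[C@]21C`) gives > 5 ug/mL, which is also a limit. Compound 2 therefore has no number of its own and stands with compound 1 at the limit of > 5 ug/mL in this assay, at which 2 of the 2 values shown sit.

Compound 3 (`CC(=O)[C@H]1[C@@H](O)CCC2=C[C@@H](O)C[C@H](C)[C@]21C`) is related to compound 2 by a single change of configuration: the two compounds have the same atoms and bonds and differ only in configuration as drawn: 1 of 5 stereo elements differ; a stereocentre at a saturated ring carbon is drawn R in compound 2 and S in compound 3. For the measured compounds named here, no measured step shows what such a change does in this assay, so no step beyond the scatter is expected in either direction. The expected change, a step that the limit leaves unreadable from compound 2 to compound 3, is only nominal, and another limit is the likeliest report. For compound 3 the estimated value is 8 ug/mL, with an expected range from 3 ug/mL to 25 ug/mL.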

Compound 3, concentration for half-maximal effect: > 5 ug/mL
Compound 3: only a limit was reported; the forecaster's own chance of this, stated with the estimate: 75%; the middle value does not contradict the limit.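

In this assay compound 3 gives > 5 ug/mL, which is again a limit. Its steps from compound 1 and compound 2 cannot be read: the limit of > 5 ug/mL in this assay, at which 3 of the 3 values shown sit.

The compounds shown leave open whether the configuration change or the loss of formyl alters cytotoxicity at all.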